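The compounds below may be only part of what the source reports. "The series", "measured", "known", "first", "only" and "open" are said of these compounds alone.

In an ADME assay on the whole organism (Macaca fascicularis) for metabolic stability, read by LC-MS, using cassette dosing, at a dose of 1 mg/kg by the oral route (on this read-out higher numbers stand for a longer-lived compound and lower numbers for a shorter-lived compound), compound 2 `CCCCN(c1nc2c(C(=O)O)cccc2o1)[C@H](C)c1ccc(-c2cc(Cl)ccc2-c2nc(=O)o[nH]2)cc1` gives 2 h, the higher of the two numbers measured, since compound 1 `C[C@H](c1ccc(-c2cc(Cl)ccc2-c2nc(=O)o[nH]2)cc1)N(CC1CC1)c1nc2c(C(=O)O)cccc2o1` gives 0.8 h and the change a 2.5-fold higher number from compound 1 to compound 2 (0.40 log units; beyond the scatter) lies beyond the scatter. Compound 3 `CCCCN(c1nc2c(C(=O)O)cccc2o1)[C@H](C)c1ccc(-c2cc(F)ccc2-c2nc(=O)o[nH]2)cc1` differs from compound 2 by fluoro in place of chloro on an aromatic carbon. Among the measured compounds shown here, no measured step touches this position; the only step known concerns the chain on the nitrogen, so nothing measured bears on the halogen swap. A step of no more than the scatter is therefore expected, no change at the digits printed from compound 2 to compound 3 (within the scatter), in this assay. Compound 3 is expected to give 2 h, within a range from 1 h to 4 h.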

Compound 3, half-life: 2.2 h
For compound 3 the middle estimate is 1.1-fold (0.04 log units) below the measured one, and the stated range covers the measured number.
By their numbers in this assay, from the lowest: compound 1; then compounds 2 and 3 (each within the scatter of the next).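

In this assay, the swap on this aromatic carbon, meta to a large group and para to a group of 6 heavy atoms, gives a 1.1-fold higher number from compound 2 to compound 3 (0.04 log units; within the scatter) and so stays within the scatter. The earlier step concerned only the chain on the nitrogen, whereas this result shows that half-life in this read-out does not separate chloro from fluoro at this position. Nothing available gives a reason for this result. From the compounds shown here alone, whether a larger group, such as trifluoromethyl or a nitrile, or plain hydrogen would read the same here remains open. So does whether fluoro would match chloro alongside the cyclopropyl-bearing chain of compound 1.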